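An oxadiazole analogue after the loss seen in compound 2

The compounds below may be only part of what the source reports. "The series", "measured", "known", "first", "only" and "open" are said of these compounds alone.

Compound 1, `CCS(=O)(=O)Nc1cccnc1-c1ccc(C(=O)Nc2ccc(C(C)(C)C)cc2)cc1`, gives 4 nM in a functional assay for antagonist activity at transient receptor potential cation channel subfamily V member 1 (Rattus norvegicus); a higher number here means a weaker inhibitor, a lower number a stronger inhibitor.
Compound 2, `CC(C)(C)c1ccc(NC(=O)c2ccc(-c3ncccc3C(=N)N)cc2)cc1`, gives > 4000 nM in this assay.

Compound 2 stands at the limit of this assay, (the limit of > 4000 nM in this assay, at which 1 of the 2 values shown sits), so only a bound is known for it. Within the data shown here, the step of an at least 1000-fold higher number from compound 1 to compound 2 (3.00 log units; beyond the scatter) shows how sharply the number rose when the group present in compound 1 was exchanged for the one present in compound 2. Compound 3, `Cc1nnc(-c2cccnc2-c2ccc(C(=O)Nc3ccc(C(C)(C)C)cc3)cc2)o1`, takes that group away again: a group of 6 heavy atoms (3 carbon, 2 nitrogen, 1 oxygen; one five-membered aromatic ring with 3 hetero atoms) in place of a group of 3 heavy atoms (1 carbon, 2 nitrogen; no ring), on an aromatic carbon. Among the measured compounds shown here, the only measured step bearing on this change is an at least 1000-fold higher number from compound 1 to compound 2 (3.00 log units; beyond the scatter), and it indicates that the group in compound 2 goes with a weak value; its exchange for a ring with no net charge is expected to bring the number down, an at least 26-fold lower number from compound 2 to compound 3 (1.42 log units; beyond the scatter), though not necessarily to the level of compound 1. Compound 3 is therefore estimated at 150 nM, within 10 nM to 3000 nM.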

Compound 3, half-maximal inhibitory concentration: 34 nM
For compound 3 the middle estimate is 4.4-fold (0.64 log units) above the measured one; the range from low to high includes it.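

On this aromatic carbon, two atoms from the ring nitrogen, 5-methyl-1,3,4-oxadiazol-2-yl gives a far lower number in this assay than the group it replaces (an at least 110-fold lower number from compound 2 to compound 3 (2.07 log units; beyond the scatter)). The (ethylsulfonyl)amino group is thus not the only one that gives a low number here, though the oxadiazole does not fully match it (an 8.5-fold higher number from compound 1 to compound 3 (0.93 log units; beyond the scatter)). The value of compound 2 is a limit and not a number, so the first step has only a bound: (the limit of > 4000 nM in this assay, at which 1 of the 3 values shown sits).

The compounds shown leave open how an amine or a carboxylic acid would behave on this carbon. They also leave open what an oxadiazole with ethyl in place of methyl would give.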